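Hydroxy Addition on the Dimethoxy Biphenyl Core

The source may hold more compounds than are shown below. What is called first, only, known or untested is meant among the compounds shown, and "the series" means these compounds.

Measured so far:
compound 1 `COc1ccccc1-c1ccccc1O`, 2.7 ug/mL
compound 2 `COc1ccc(-c2ccccc2)c(OC)c1`, 55.2 ug/mL

In a functional assay on HT-29 cells (Homo sapiens) for cytotoxicity, read by MTT assay, with a stated time of 3 days (a lower number here means a stronger inhibitor, a higher number a weaker inhibitor), compound 1 gives 2.7 ug/mL and compound 2 gives 55.2 ug/mL. Compound 2 has the higher of the two numbers, and its gap to compound 1 lies beyond the scatter. Compound 3 `COc1ccc(-c2ccccc2O)c(OC)c1` is not yet measured; it differs from compound 2 by hydroxy in place of hydrogen on an aromatic carbon. Compound 1 also carries a hydroxy ortho to a large group and gives 2.7 ug/mL. On that basis the step of a 6.9-fold lower number from compound 2 to compound 3 (0.84 log units; beyond the scatter) in this assay is expected to be a fall beyond the scatter. For compound 3 a value of 8 ug/mL is estimated, with a range of 2.5 ug/mL to 25 ug/mL.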

Compound 3, half-maximal inhibitory concentration: 33.7 ug/mL
For compound 3 the middle estimate is 4.2-fold (0.62 log units) below the measured one; measured number above the stated range.
By their numbers in this assay, from the lowest: compound 1; then compounds 3 and 2 (each within the scatter of the next).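

In this assay hydroxy in place of hydrogen on an aromatic carbon, ortho to a large group, gives a 1.6-fold lower number from compound 2 to compound 3 (0.21 log units; within the scatter) and so does not by itself separate these two compounds. The large step lies instead with the added methoxy, a 12-fold higher number from compound 1 to compound 3 (1.10 log units; beyond the scatter) on the core of compound 1. No supporting data bear on why either step has its size. Open, going by these compounds, is whether an amine or a carboxylic acid in place of the hydroxy would give a step beyond the scatter on this core.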